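Swapping the aryl group of compound 3 for an arylamino group

This account rests on a few compounds, and the source may have more. Where it says the series, first, only, none or still open, it means among the compounds named here.

- compound 1 `COc1cc(C(=O)c2sc3ccccc3c2-c2ccc(Cl)cc2)cc(OC)c1OC` gives 4200 nM
- compound 2 `COc1cc(C(=O)c2sc3ccccc3c2-c2ccc(SC)cc2)cc(OC)c1OC` gives 1800 nM
- compound 3 `CCOc1ccc(-c2c(C(=O)c3cc(OC)c(OC)c(OC)c3)sc3ccccc23)cc1` gives 3100 nM

All three values come from a functional assay on K562 cells (Homo sapiens) for antiproliferative activity, read by MTT assay, with a stated time of 72 h; on this read-out higher numbers stand for weaker inhibition and lower numbers for stronger inhibition. Compound 3 stands among the other two rather than apart from them, since it lies within the scatter of each: the change is a 1.4-fold lower number from compound 1 to compound 3 (0.13 log units; within the scatter) on one side and a 1.7-fold higher number from compound 2 to compound 3 (0.24 log units; within the scatter) on the other. Only the outer pair is separated beyond the scatter, by a 2.3-fold lower number from compound 1 to compound 2 (0.37 log units; beyond the scatter), which is a modest step.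

Compound 4 `COc1ccc(Nc2c(C(=O)c3cc(OC)c(OC)c(OC)c3)sc3ccccc23)cc1` has not yet been measured. It carries (4-methoxyphenyl)amino in place of 4-ethoxyphenyl on an aromatic carbon. This change is of another kind from the three measured steps, each of which exchanges one group on an aromatic carbon while the aromatic ring that bears it stays attached in the same way. Those steps therefore bear on it only indirectly. Within the data shown here, they show a narrow spread, and the data hold no compound with the new amino link, so the uncertainty is wide.

No step beyond the scatter is expected, and the expected step is a 1.6-fold lower number from compound 3 to compound 4 (0.19 log units; within the scatter). For compound 4 the estimate is 2000 nM, with an expected range from 300 nM to 8000 nM.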

Compound 4, half-maximal inhibitory concentration: 2900 nM
Compound 4: the middle estimate sits 1.5-fold (0.16 log units) below what was measured; the measured number falls inside the stated range.
By their numbers in this assay, from the lowest: compounds 2, 4, 3 and 1 (each within the scatter of the next, the first and the last beyond it).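

In this assay, the place next to the ring atom that bears a large group, two ring bonds from the ring sulfur, accepts an amino link as well as a direct aryl attachment, at least on this read-out: a 1.1-fold lower number from compound 3 to compound 4 (0.03 log units; within the scatter). Among these compounds, the link brings a hydrogen-bond donor that none of the earlier compounds carries, yet compound 4 is separated from neither of the other two, with a 1.6-fold higher number from compound 2 to compound 4 (0.21 log units; within the scatter) and a 1.4-fold lower number from compound 1 to compound 4 (0.16 log units; within the scatter), so it joins the same narrow band rather than opening a new level of activity. No independent measurement is available that would account for this result.

Since the ethoxy group gave way to methoxy in the same step, the compounds shown do not separate the effect of the link from that of the group at the end of the ring, and a (4-chlorophenyl)amino or (4-ethoxyphenyl)amino group would be needed to do so. As far as these compounds go, it also remains open whether a methylene or carbonyl link, or a methylated amino link, would fit this place equally well.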